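A Fluorine Added to the Phenoxy Ring of Compound 2

The source may report more compounds than this note shows. Statements on the series, on what has been measured and on what is new or still open speak of the compounds shown alone.

Compound 1 `O=C(O)COc1ccc(NC(=O)COc2ccccc2)cc1F` gives 29.8% in a functional assay on CHO cells for agonist activity at Free fatty acid receptor 1 (Homo sapiens), read by FLIPR, tested at 100 nM; a lower number here means a weaker effect, a higher number a stronger effect of the compound at the concentration tested.
Compound 2 `CC(Oc1ccccc1)C(=O)Nc1ccc(OCC(=O)O)c(F)c1` gives 35.7% in this assay.
Compound 3 `CC(C)(Oc1ccccc1)C(=O)Nc1ccc(OCC(=O)O)c(F)c1` gives 3.56% in this assay.

Compound 2 holds the highest of the three numbers, though the first step, a number 5.9 percentage points higher from compound 1 to compound 2 (within the scatter), stays within the scatter; the second step, a number 32.1 percentage points lower from compound 2 to compound 3 (beyond the scatter), is far larger.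

The next compound, compound 4 `CC(Oc1ccccc1F)C(=O)Nc1ccc(OCC(=O)O)c(F)c1`, is compound 2 with one change: fluoro in place of hydrogen on an aromatic carbon.

Among the measured compounds shown here, no measured step speaks to this change. Both known steps concern a methyl in place of hydrogen on the saturated chain carbon: one, from compound 1 to compound 2, stayed within the scatter, while the other, from compound 2 to compound 3, was large. For the measured compounds named here, neither touches the phenoxy ring, so the fluoro step has no precedent here. Lacking one, the expected step in this assay is none beyond the scatter, with wide uncertainty: the estimated change is a number 0.7 percentage points lower from compound 2 to compound 4 (within the scatter). Compound 4 is therefore estimated at 35%, within a range of 15% to 55%.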

Compound 4, a percentage reported as activity, at one concentration (the size of the read-out at that concentration, not a potency): 35.1%
Beside the measured number, compound 4's estimate is 0.1 percentage points below it; the range from low to high includes it.
By their numbers in this assay, from the lowest: compound 3; then compounds 1, 4 and 2 (each within the scatter of the next).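

Among the compounds shown here, the phenoxy ring is changed here for the first time, and fluoro in place of hydrogen, ortho to a large group, gives a number 0.6 percentage points lower from compound 2 to compound 4 (within the scatter) in this assay. So this one change on the ring leaves the read-out indistinguishable from that of compound 2, whereas the added methyl on the chain carbon gave a number 32.1 percentage points lower from compound 2 to compound 3 (beyond the scatter). Nothing measured here accounts for the result at this ring position.

A single fluoro at one place says little about the rest of the phenoxy ring, so a chloro, methyl or methoxy group at the same place remains an open question. Also open, from the compounds shown here alone, is whether fluoro on another carbon of that ring, or a second fluoro, would give a read-out beyond the scatter from that of compound 2.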